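The source may report more compounds than this note shows. Statements on the series, on what has been measured and on what is new or still open speak of the compounds shown alone.

Two compounds built on a shared core have numbers in a functional assay on T47D cells (Homo sapiens) for inhibition, read by CCK-8 assay, with a stated time of 72 h, tested at 1 uM; a higher number here means more inhibition of growth at the concentration tested, a lower number less inhibition of growth. Compound 1 `CN(C)C(=O)c1cc2cnc(Nc3ccc(NC(=O)C4(C(=O)Nc5ccccc5F)CC4)cc3)nc2n1C1CCCC1` gives 85.2%, and compound 2 `CN(C)C(=O)c1cc2cnc(Nc3ccc(NC(=O)C4(C(=O)Nc5ccc(Br)cc5)CC4)cc3)nc2n1C1CCCC1` gives 21.1%, the lower of the two. Compound 3 `Cc1ccc(NC(=O)C2(C(=O)Nc3ccc(Nc4ncc5cc(C(=O)N(C)C)n(C6CCCC6)c5n4)cc3)CC2)cc1` has not yet been measured. It differs from compound 2 at a single place: methyl in place of bromo on an aromatic carbon.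

Among the compounds with values here, no measured step makes this exchange. The only one that bears on it is a number 64.1 percentage points lower from compound 1 to compound 2 (beyond the scatter), where 4-bromophenyl took the place of 2-fluorophenyl on an amide-type nitrogen. That step was large, so the read-out can respond strongly to a change in this group, but it does not compare bromo with methyl. Since the new methyl stays where the bromo stood, compound 3 is expected to remain nearer to compound 2 than to compound 1. The expected change is a modest rise, estimated as a number 13.9 percentage points higher from compound 2 to compound 3 (beyond the scatter). The estimate for compound 3 is 35%, with an expected range from 12% to 68%.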

Compound 3, percent growth inhibition at one concentration: 47.9%
For compound 3 the middle estimate is 12.9 percentage points below the measured one; the range from low to high includes it.
By their numbers in this assay, from the lowest: compound 2; then compound 3; then compound 1.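

With the ring and its place held fixed, the exchange in this assay gives a number 26.8 percentage points higher from compound 2 to compound 3 (beyond the scatter), so the group para to a large group affects the read-out by its identity and not only by its place on the ring. The earlier step could not show this, since it changed both the substituent and where it stood. Methyl recovers only part of the difference, however, with a number 37.3 percentage points lower from compound 1 to compound 3 (beyond the scatter), and the data offer no measured explanation for the gap between bromo and methyl or for that remaining gap.

The compounds shown leave open whether the shortfall of compound 2 and compound 3 relative to compound 1 follows from the substituent's identity or from its place on the ring, and a fluoro on this same aromatic carbon would separate the two. They also leave open how a methoxy group, an amine or a carboxylic acid at this place would compare with methyl and bromo, so no trend across substituents can yet be drawn from this pair alone.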